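Compound 4: clearance after the 4-cyclopropylphenyl change

The source may report more compounds than this note shows. Statements on the series, on what has been measured and on what is new or still open speak of the compounds shown alone.

In an ADME assay on microsomes from liver (Canis lupus familiaris) for metabolic stability, read by LC-MS, using NADPH, with a stated time of 10 min, tested at 0.1 uM (on this read-out higher numbers stand for fast clearance and lower numbers for slow clearance), compound 3 `O=C(NCCCCc1ccccc1)c1cccc(C2SCC(=O)N2c2cccc(F)c2)c1` gives 837 mL.min-1.g-1, the second highest of the three numbers. Compound 1 `CC1SC(c2cccc(C(=O)NCCCCc3ccccc3)c2)N(c2ccc(C3CC3)cc2)C1=O` lies higher at 1750 mL.min-1.g-1, and compound 2 `O=C(NCCCCc1ccccc1)c1cccc(C2SCC(=O)N2c2cccc(-c3c[nH]nn3)c2)c1` lies lower at 226 mL.min-1.g-1.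

Compound 4 `O=C(NCCCCc1ccccc1)c1cccc(C2SCC(=O)N2c2ccc(C3CC3)cc2)c1` places 4-cyclopropylphenyl in place of 3-fluorophenyl on an amide-type nitrogen in a ring.

Among the compounds with values here, only one measured step bears directly on this part of the molecule, a 3.7-fold higher number from compound 2 to compound 3 (0.57 log units; beyond the scatter), a modest change beyond the scatter. It involves different groups, so it gives a size rather than a direction. The closest guide is compound 1 at 1750 mL.min-1.g-1, which carries the same 4-cyclopropylphenyl group on a different core. Within the data shown here, no measured pair isolates this group.

A modest rise in this assay is therefore expected, with the estimated step being a 1.7-fold higher number from compound 3 to compound 4 (0.22 log units; within the scatter). For compound 4 the estimated value is 1400 mL.min-1.g-1, with an expected range of 750 mL.min-1.g-1 to 2600 mL.min-1.g-1.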

Compound 4, intrinsic clearance in microsomes: 1080 mL.min-1.g-1
For compound 4 the middle estimate is 1.3-fold (0.11 log units) above the measured one, and the stated range covers the measured number.
By their numbers in this assay, from the lowest: compound 2; then compounds 3, 4 and 1 (each within the scatter of the next, the first and the last beyond it).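

In this assay the exchange of 3-fluorophenyl for 4-cyclopropylphenyl on the amide-type nitrogen in a ring gives a 1.3-fold higher number from compound 3 to compound 4 (0.11 log units; within the scatter) and so shows no readable difference between these two groups at this position. Hydrogen in place of methyl on the saturated ring carbon gives a 1.6-fold lower number from compound 1 to compound 4 (0.21 log units; within the scatter) and is also not readable as a change, whereas the group bearing the 1H-1,2,3-triazol-4-yl ring stands apart in a 4.8-fold higher number from compound 2 to compound 4 (0.68 log units; beyond the scatter) on the same nitrogen. No measurement at hand offers an explanation for these numbers.

Open, going by these compounds, is whether a carboxylic acid or a primary amine on this phenyl ring would give a step as large as that seen with the 1H-1,2,3-triazol-4-yl group. Also open, on these data alone, is whether an ethyl group on the saturated ring carbon would remain within the scatter.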